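This account rests on a few compounds, and the source may have more. Where it says the series, first, only, none or still open, it means among the compounds named here.

Compound 1 `COc1nc(C)c(Nc2nc(Cl)cn([C@H](COC(=O)c3ccccn3)C3CC3)c2=O)cc1C` was tested in an assay on frontal cortex for displacement of a labelled ligand from corticotropin-releasing factor receptor 1 (Rattus norvegicus), with a stated time of 2 h (on this read-out lower numbers stand for stronger inhibition and higher numbers for weaker inhibition), and gives 67 nM. Among the measured compounds shown here, of the three compounds with a number so far, compound 1 has the highest one; the other two sit well below it. Compound 2 `COc1nc(C)c(Nc2nc(Cl)cn([C@H](COC(=O)Nc3ccccc3)C3CC3)c2=O)cc1C` gives 1.5 nM and compound 3 `COc1nc(C)c(Nc2nc(Cl)cn([C@H](COC(=O)Nc3ccccc3Cl)C3CC3)c2=O)cc1C` gives 1.5 nM, and the two change no change at the digits printed from compound 2 to compound 3 (within the scatter), so they cannot be ranked against each other.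

The compound now in question is compound 4 `COc1nc(C)c(Nc2nc(Cl)cn([C@H](COC(=O)Nc3cccc(C#N)c3)C3CC3)c2=O)cc1C`. Compared with compound 1 the change is (3-cyanophenyl)amino in place of pyridin-2-yl on a carbonyl carbon. Two of the known steps are close relatives of this one: the move to an anilino group at the same carbonyl carbon gives a 45-fold lower number from compound 1 to compound 2 (1.65 log units; beyond the scatter), and the move to a (2-chlorophenyl)amino group gives a 45-fold lower number from compound 1 to compound 3 (1.65 log units; beyond the scatter). Both are large and point the same way, and adding chloro to the aromatic ring made no further difference. A (3-cyanophenyl)amino group is a third aromatic amine of the same kind, so a step of similar size and direction is expected; the step is estimated at a 34-fold lower number from compound 1 to compound 4 (1.53 log units; beyond the scatter). Compound 4 is therefore expected to give about 2 nM, with a likely range from 0.7 nM to 6 nM.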

Compound 4, half-maximal inhibitory concentration: 1.3 nM
Compound 4: the middle estimate sits 1.5-fold (0.19 log units) above what was measured; low and high end bracket the measured number.
By their numbers in this assay, from the lowest: compounds 4, 2 and 3 (each within the scatter of the next); then compound 1.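

In this assay, the step of a 52-fold lower number from compound 1 to compound 4 (1.71 log units; beyond the scatter) joins the two earlier steps away from pyridin-2-yl, so three different aromatic amino groups on this carbonyl carbon now give numbers far below that of compound 1. The new information concerns the ring on that amino group: with a 1.2-fold lower number from compound 2 to compound 4 (0.06 log units; within the scatter) and a 1.2-fold lower number from compound 3 to compound 4 (0.06 log units; within the scatter), the 3-cyanophenyl ring cannot be told apart from the plain phenyl ring or the 2-chlorophenyl ring, so a nitrile on the ring, like the earlier chloro, leaves the number within the scatter. No measurement here offers an explanation for these results.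

The change from compound 1 to compound 2 swaps the ring and adds the amino link in one move, so a pyridin-2-ylamino group would be needed to show which of the two parts carries the large step. On these data alone, it also remains open whether a saturated cyclohexylamino group, with no aromatic ring, or an N-methylanilino group, without the amide hydrogen, would keep the number near that of compound 2.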